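The source may report more compounds than this note shows. Statements on the series, on what has been measured and on what is new or still open speak of the compounds shown alone.

Of the compounds shown here, three sharing one core have been tested in a functional assay on HepG2 cells (Homo sapiens) for cytotoxicity, read by MTT assay, with a stated time of 72 h; a higher number here means a weaker inhibitor, a lower number a stronger inhibitor. Compound 1 `Cc1ccc(-n2nc(C(=O)Nc3ccc(Oc4ncnc5[nH]ccc45)cc3)c(C)cc2=O)cc1` gives 7460 nM. Compound 2 `Cc1cc(=O)n(-c2ccccc2OC(F)(F)F)nc1C(=O)Nc1ccc(Oc2ncnc3[nH]ccc23)cc1` gives 22800 nM, which is the highest of the two plain numbers, with compound 1 the nearest. The step of a 3.1-fold higher number from compound 1 to compound 2 (0.49 log units; beyond the scatter) corresponds to 2-(trifluoromethoxy)phenyl in place of 4-methylphenyl on an aromatic nitrogen. Compound 3 `Cc1cc(=O)n(-c2ccccc2OC(F)(F)F)nc1C(=O)Nc1ccc(Oc2ncnc3[nH]ccc23)c(F)c1` reaches only a limit of the assay, > 60000 nM. The step of an at least 2.6-fold higher number from compound 2 to compound 3 (0.42 log units; beyond the scatter) is fluoro in place of hydrogen on an aromatic carbon, and it ends at the limit of > 60000 nM in this assay, at which 1 of the 3 values shown sits.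

Compound 4 `Cc1cc(=O)n(-c2ccccc2OC(F)(F)F)nc1C(=O)Nc1ccc(Oc2ncnc3c2ccn3C)cc1` has not yet been measured. It differs from compound 2 by methyl in place of hydrogen on an aromatic nitrogen. Neither measured step touches this place, so none bears on it directly; both known steps were modest and both gave a higher number. For compound 4 the expected step is a 1.3-fold higher number from compound 2 to compound 4 (0.12 log units; within the scatter), likely within the scatter or a little weaker. Compound 4 is therefore estimated at 30000 nM, with a range from 12000 nM to 75000 nM.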

Compound 4, half-maximal inhibitory concentration: > 60000 nM
Compound 4: a limit, no number; the forecaster's own chance of this, stated with the estimate: 25%; at least 2.0-fold (0.30 log units) between middle value and limit.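

Going by these compounds alone, the first change at this nitrogen of the shared core already has a clear effect: methyl in place of hydrogen on an aromatic nitrogen gives an at least 2.6-fold higher number from compound 2 to compound 4 (0.42 log units; beyond the scatter) in this assay. The earlier steps changed the aryl group or added a fluoro, so this is the first sign that the hydrogen on the five-membered ring cannot be replaced without a cost, and all three single changes shown have raised the number. Compound 4 gives only a limit of the assay, not a number, and it is a limit shared with one other compound: the limit of > 60000 nM in this assay, at which 2 of the 4 values shown sit.

Going by these compounds, it remains open how much higher the true value of compound 4 lies. Also open, on these data alone, is whether an ethyl group, a longer chain or a chain ending in an amine on this nitrogen would give a measurable number.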